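The source may report more compounds than this note shows. Statements on the series, on what has been measured and on what is new or still open speak of the compounds shown alone.

Measured compounds:
- compound 1, `Cc1c(Cc2c(F)cccc2Cl)nc(SCC(=O)c2ccccc2)[nH]c1=O`: > 12000 nM
- compound 2, `Cc1c(Cc2c(F)cccc2Cl)nc(SCC(=O)c2ccc(F)cc2)[nH]c1=O`: > 59000 nM
- compound 3, `Cc1c(Cc2c(F)cccc2F)nc(SCC(=O)c2ccccc2)[nH]c1=O`: 65000 nM

All three were tested in an ADME assay on MT4 cells (Homo sapiens) for cytotoxicity, read by MTT assay; on this read-out lower numbers stand for higher toxicity in this test and higher numbers for lower toxicity in this test. For compound 1 the result is a limit of the test, not a number: > 12000 nM. For compound 2 the result is also a limit, not a number: > 59000 nM. Going by the values given here, compound 3 is the only one with a real number, 65000 nM.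

Compound 2 is made from compound 1 by one change, (fluoro in place of hydrogen on an aromatic carbon). The step that the two limits leave unreadable from compound 1 to compound 2 cannot be sized because both values sit at limits, the limit of > 12000 nM in this assay, at which 1 of the 3 values shown sits, and (the limit of > 59000 nM in this assay, at which 1 of the 3 values shown sits). Compound 3 differs from compound 1 in its core: fluoro in place of chloro on an aromatic carbon. That step, a step that the limit leaves unreadable from compound 1 to compound 3, is likewise unreadable because the value of compound 1 is a limit, (the limit of > 12000 nM in this assay, at which 1 of the 3 values shown sits).

Compound 4, `Cc1c(Cc2c(F)cccc2F)nc(SCC(=O)c2ccc(F)cc2)[nH]c1=O`, has not yet been measured. It is made from compound 3 by fluoro in place of hydrogen on an aromatic carbon, the same change that turns compound 1 into compound 2. What that change did cannot be read from a step that the two limits leave unreadable from compound 1 to compound 2, so the expectation rests mainly on compound 3 and its value 65000 nM, with compound 2 only showing that the fluoro-bearing compound stayed low in toxicity. The step from compound 3 to compound 4 is expected to be small, a 1.1-fold higher number from compound 3 to compound 4 (0.03 log units; within the scatter). Compound 4 is therefore estimated at 70000 nM, between 30000 nM and 160000 nM.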

Compound 4, half-maximal cytotoxic concentration: > 62000 nM
Compound 4 was reported as a limit (the forecaster's own chance of this, stated with the estimate: 50%); the middle value is on the limit's open side.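

In this assay compound 4 gives > 62000 nM as a limit of the test and not a number. Going by these compounds alone, with this result, no step can be sized from compound 3 to compound 4 or from compound 2 to compound 4. The compounds shown leave open how far, if at all, going from phenyl to 4-fluorophenyl moves the cytotoxic concentration in either pair of compounds.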